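From ester to hydroxymethyl on a shared core

The source may report more compounds than this note shows. Statements on the series, on what has been measured and on what is new or still open speak of the compounds shown alone.

In a functional assay on SW480 cells (Homo sapiens) for cytotoxicity, read by MTT assay, with a stated time of 48 h (on this read-out lower numbers stand for stronger inhibition and higher numbers for weaker inhibition), compound 3 `CCOC(=O)[C@@]1(C(=O)Nc2ccccc2Cl)C[C@@H]1c1cc(OC)c(OC)c(OC)c1` gives 46700 nM. This is the higher of the two actual numbers available, since compound 1 `COc1cc([C@@H]2C[C@]2(CO)C(=O)Nc2ccccc2Cl)cc(OC)c1OC` gives 13200 nM, a lower number by a margin beyond the scatter. Compound 2 `CCOC(=O)[C@@]1(C(=O)Nc2ccccc2)C[C@@H]1c1cc(OC)c(OC)c(OC)c1` reads > 100000 nM, which is a limit of the assay.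

The next structure is compound 4 `COc1cc([C@H]2C[C@@]2(CO)C(=O)Nc2ccccc2Cl)cc(OC)c1OC`. The change is hydroxymethyl in place of ethoxycarbonyl on a saturated ring carbon. Among the measured compounds shown here, the only measured step, an at least 2.1-fold lower number from compound 2 to compound 3 (0.33 log units; beyond the scatter), is chloro in place of hydrogen on an aromatic carbon, so it occurs elsewhere on the molecule and offers little guidance here. The closer guide is the mirror-image relationship: compound 4 is the mirror image of compound 1, which also carries hydroxymethyl and gives 13200 nM. How far that value carries across the mirror is unmeasured, so only a moderate drop in the number is expected. The expected change is a 2.3-fold lower number from compound 3 to compound 4 (0.37 log units; beyond the scatter). For compound 4 the estimated value is 20000 nM, with an expected range of 6000 nM to 70000 nM.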

Compound 4, half-maximal inhibitory concentration: > 100000 nM
Compound 4: a limit, no number (the forecaster's own chance of this, stated with the estimate: 12%); at least 5.0-fold (0.69 log units) between middle value and limit.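

In this assay, compound 4 gives > 100000 nM, which is a limit and not a number, and hydroxymethyl in place of ethoxycarbonyl on a saturated ring carbon here brings an at least 2.1-fold higher number from compound 3 to compound 4 (0.33 log units; beyond the scatter). Among the compounds shown here, the hydroxymethyl group therefore does not carry the lower number of compound 1 with it, as the shared atoms bring an at least 7.5-fold higher number from compound 1 to compound 4 (0.87 log units; beyond the scatter), a gap that rests on configuration alone, which the earlier compounds could not show: the fact that compounds 1 and 4 differ only in the configuration as drawn. As far as these compounds go, the true size of both steps remains unknown, since compound 4 shares its limit with compound 2: the limit of > 100000 nM in this assay, at which 2 of the 4 values shown sit.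

What the compounds shown leave open is how the mirror image of compound 3 would read in this assay. From the compounds shown here alone, it is also open whether a carboxylic acid or an aminomethyl group on this saturated ring carbon would follow the same dependence on configuration.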